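Methyl in Place of Hydrogen on Compound 2

The compounds below may be only part of what the source reports. "The series", "measured", "known", "first", "only" and "open" are said of these compounds alone.

Compound 2 `O=C(O)CCc1ccc(C#Cc2ccnc(F)c2)cc1` gives 98% in an in vitro functional assay on 1321-N1 cells for agonist activity at Free fatty acid receptor 1 (Homo sapiens), read by fluorescence, spectrophotometry and calcium flux (on this read-out lower numbers stand for smaller maximal responses and higher numbers for larger maximal responses), the highest of the three numbers though within the scatter of the others: compound 3 `O=C(O)CCc1ccc(C#Cc2ccnc(Cl)c2)cc1` gives 94% and compound 1 `Cc1ccccc1-c1cc(C#Cc2ccc(CCC(=O)O)cc2)ccn1` gives 92%, with a number 4 percentage points lower from compound 2 to compound 3 (within the scatter) and a number 6 percentage points higher from compound 1 to compound 2 (within the scatter). Compound 4 `Cc1cnc(F)cc1C#Cc1ccc(CCC(=O)O)cc1` differs from compound 2 by methyl in place of hydrogen on an aromatic carbon. Among the measured compounds shown here, none of the measured steps adds a methyl group; all three swap one group for another on an aromatic carbon, and all stayed within the scatter, a number 2 percentage points higher from compound 1 to compound 3 (within the scatter) included. Since every measured compound reaches a full response in this assay, compound 4 is expected to do so as well, with a number 3 percentage points lower from compound 2 to compound 4 (within the scatter) expected to lie within the scatter. The estimated value of compound 4 in this assay is 95%, between 85% and 105%.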

Compound 4, largest response reached (reported as efficacy), in percent of the reference or control that the assay uses: 99%
Beside the measured number, compound 4's estimate is 4 percentage points below it; measured number inside the range.
By their numbers in this assay, from the lowest: compounds 1, 3, 2 and 4 (each within the scatter of the next).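

In this assay, methyl in place of hydrogen on this aromatic carbon, ortho to a large group, two atoms from the ring nitrogen and para to the fluoro group, gives a step inside the scatter (a number 1 percentage points higher from compound 2 to compound 4 (within the scatter)). Among the compounds shown here, the position therefore takes a methyl group with the full response kept, which no earlier compound could show, since all of them carry hydrogen there. Nothing available explains this result.

The compounds shown leave open whether a longer chain, a methoxy group or an amine at this position would also keep the full response. A maximal response also says nothing about the concentration needed to reach it.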